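Changing the Amine at the End of the Side Chain

The compounds below may be only part of what the source reports. "The series", "measured", "known", "first", "only" and "open" are said of these compounds alone.

Measured compounds:
- compound 1 `COc1cc2c(Nc3ccc(C#N)cc3)ncnc2cc1OCCCN1CCC(C)CC1`: 16600 nM
- compound 2 `COc1cc2c(Nc3ccc(C#N)cc3)ncnc2cc1OCCCN1CCCCC1CCO`: the result is a limit, > 100000 nM

Among the compounds with values here, in a functional assay on DU-145 cells (Homo sapiens) for antiproliferative activity, read by MTT assay, with a stated time of 72 h (a higher number here means a weaker inhibitor, a lower number a stronger inhibitor), compound 1 gives 16600 nM, and this is the only actual number among the two measured compounds. For compound 2 the outcome in this assay is a limit rather than a number, > 100000 nM. Within the data shown here, the single measured step, an at least 6.0-fold higher number from compound 1 to compound 2 (0.77 log units; beyond the scatter), shows that exchanging the 4-methylpiperidin-1-yl at this position for another amine weakens inhibition, and because of the limit of > 100000 nM in this assay, at which 1 of the 2 values shown sits, the true size of that weakening is not known. Compound 3 `COc1cc2c(Nc3ccc(C#N)cc3)ncnc2cc1OCCCN1CCN(c2ccncc2)CC1` carries a change of the same kind at the same place: 4-(pyridin-4-yl)piperazin-1-yl in place of 4-methylpiperidin-1-yl on a saturated chain carbon, three bonds along the chain from an oxygen on an aromatic ring. Among the measured compounds shown here, since the only comparable exchange gave an at least 6.0-fold higher number from compound 1 to compound 2 (0.77 log units; beyond the scatter), compound 3 is expected to be weaker than compound 1, by an estimated step of a 3.0-fold higher number from compound 1 to compound 3 (0.48 log units; beyond the scatter). Compound 3 is therefore estimated at 50000 nM, within a range from 15000 nM to 150000 nM, with a real chance that this assay again returns only a limit.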

Compound 3, half-maximal inhibitory concentration: 22900 nM
Estimate against measurement, compound 3: 2.2-fold (0.34 log units) above, and the stated range covers the measured number.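

In this assay, swapping 4-methylpiperidin-1-yl for the bigger 4-(pyridin-4-yl)piperazin-1-yl leaves the result unchanged, with a 1.4-fold higher number from compound 1 to compound 3 (0.14 log units; within the scatter). A new amine at this place therefore does not weaken inhibition by itself, and the loss seen so far is tied to 2-(2-hydroxyethyl)piperidin-1-yl rather than to every exchange, as an at least 4.3-fold lower number from compound 2 to compound 3 (0.64 log units; beyond the scatter) shows. The value of compound 2 is a limit, and the true size of this last step stays unknown because of it: the limit of > 100000 nM in this assay, at which 1 of the 3 values shown sits.

Going by these compounds, whether the loss in compound 2 comes from the hydroxyethyl group itself or from where it sits remains open, and 4-(2-hydroxyethyl)piperidin-1-yl would be the direct comparison. How morpholin-4-yl or an open-chain dimethylamino group would behave at this place is also unknown.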